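Methyl in place of hydrogen on the chain of compound 1

This account rests on a few compounds, and the source may have more. Where it says the series, first, only, none or still open, it means among the compounds named here.

Compound 1 `c1ccc(CCC2=NCCN2)cc1`: 3720 nM
Compound 2 `c1ccc(C(CC2=NCCN2)c2ccccc2)cc1`: 3090 nM

Among the measured compounds shown here, in an assay on PC-12 cells for binding affinity to Nischarin (Rattus norvegicus) (on this read-out higher numbers stand for weaker inhibition and lower numbers for stronger inhibition), compound 1 gives 3720 nM, the highest of the two numbers so far, and compound 2 gives 3090 nM, the nearest to it. For the measured compounds named here, the step of a 1.2-fold lower number from compound 1 to compound 2 (0.08 log units; within the scatter) is the only measured change at this part of the shared core.

Compound 3 `C[C@@H](CC1=NCCN1)c1ccccc1` has not yet been measured in this assay. It differs from compound 1 by methyl in place of hydrogen on a saturated chain carbon bound to an aromatic carbon and a saturated chain carbon. Going by the values given here, the one measured step that bears on this change is the step that also places a new group on this same saturated chain carbon, a 1.2-fold lower number from compound 1 to compound 2 (0.08 log units; within the scatter), and it stayed within the scatter. Among the compounds with values here, a methyl is a smaller group than the phenyl entering there in compound 2, and there is no further measured compound to show anything else about this position. The expectation is therefore that the step from compound 1 to compound 3 is small, a 1.1-fold lower number from compound 1 to compound 3 (0.03 log units; within the scatter), with no direction beyond the scatter. Compound 3 is estimated at 3500 nM in this assay, in the range 1500 nM to 8000 nM.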

Compound 3, inhibition constant: 7240 nM
Compound 3: middle estimate off by 2.1-fold (0.32 log units), on the low side; the range from low to high includes it.
By their numbers in this assay, from the lowest: compounds 2, 1 and 3 (each within the scatter of the next, the first and the last beyond it).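

In this assay a second group on the saturated chain carbon bound to an aromatic carbon and a saturated chain carbon also stays within the scatter, with methyl in place of hydrogen giving a 1.9-fold higher number from compound 1 to compound 3 (0.29 log units; within the scatter) and phenyl in place of hydrogen giving a 1.2-fold lower number from compound 1 to compound 2 (0.08 log units; within the scatter), so neither of the two entering groups separates clearly from hydrogen at this position. Among the compounds shown here, what the earlier compounds could not show is that the choice of group here can still matter: compound 2 at 3090 nM and compound 3 at 7240 nM lie beyond the scatter of each other, although each lies within the scatter of compound 1. No accompanying measurement bears on why these numbers fall as they do.

The compounds shown leave open whether an ethyl, a hydroxyl or an amine on this same chain carbon would also stay within the scatter of compound 1, or would fall outside it. They also leave open how a methyl on the other saturated chain carbon, the one bound to the core, would compare with the methyl of compound 3.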